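This account rests on a few compounds, and the source may have more. Where it says the series, first, only, none or still open, it means among the compounds named here.

Working notes on the series. Compound 1 `NC1=NC2(CCOCC2)N(OCCCOc2ccc(Cl)c(Cl)c2)C(N)=N1` is measured in a functional assay on MDA-MB-231 cells (Homo sapiens) for antiproliferative activity, read by MTT assay, with a stated time of 72 h (on this read-out lower numbers stand for stronger inhibition and higher numbers for weaker inhibition), at 590 nM. Among the three numbers so far it stands second highest: compound 2 `NC1=NC2(CCSCC2)N(OCCCOc2ccc(Cl)cc2)C(N)=N1` gives 350 nM in this assay, and compound 3 `NC1=NC2(CCOCC2)N(OCCCOc2ccccc2Br)C(N)=N1` gives 910 nM; both of these lie within the scatter of compound 1, so no order among the three can be read from them.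

The unmeasured compound 4 `Cc1cc(C)cc(OCCCON2C(N)=NC(N)=NC23CCOCC3)c1` differs from compound 1 in one place: 3,5-dimethylphenyl in place of 3,4-dichlorophenyl on an oxygen on a saturated carbon.

Within the data shown here, the only measured step that touches the same place is the one between compound 1 and compound 3, a 1.5-fold higher number from compound 1 to compound 3 (0.19 log units; within the scatter). Among the measured compounds shown here, that exchange of the group on the oxygen moved the number by an amount inside the scatter, and no other step in this assay bears on the change. On that basis the step to compound 4 is expected to be small as well, a 1.2-fold higher number from compound 1 to compound 4 (0.07 log units; within the scatter), with no direction claimed beyond the scatter.

For compound 4 the estimate in this assay is therefore 700 nM, with the range running from 300 nM to 1700 nM.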

Compound 4, half-maximal inhibitory concentration: 3570 nM
Beside the measured number, compound 4's estimate is 5.1-fold (0.71 log units) below it; measured number above the stated range.
By their numbers in this assay, from the lowest: compounds 2, 1 and 3 (each within the scatter of the next, the first and the last beyond it); then compound 4.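

In this assay, the group on the oxygen on a saturated carbon proves able to move the number beyond the scatter: 3,5-dimethylphenyl gives a 6.1-fold higher number from compound 1 to compound 4 (0.78 log units; beyond the scatter) and a 3.9-fold higher number from compound 3 to compound 4 (0.59 log units; beyond the scatter). Among these compounds, the only earlier step at this place stayed within the scatter, so the position is not indifferent to its group, even though 3,4-dichlorophenyl and 3,5-dimethylphenyl have the same count of heavy atoms. Nothing available accounts for the higher number of compound 4.

Compound 4 changes both the substituents and their places on the ring, so the compounds shown do not separate these two changes. Going by these compounds, it also remains open how 3,5-dichlorophenyl or 3,4-dimethylphenyl would read at this place, and whether the step carries over to the core of compound 2.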